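The compounds below may be only part of what the source reports. "The series", "measured", "known", "first", "only" and "open" are said of these compounds alone.

Measured so far in a functional assay on Ishikawa cells (Homo sapiens) for inhibition, read by MTT assay, with a stated time of 48 h; a lower number here means a stronger inhibitor, a higher number a weaker inhibitor:
- compound 1 (`CCOC(=O)c1c(N)sc(/N=C/c2ccc([N+](=O)[O-])o2)c1C(=O)OCC`) gives 7600 nM
- compound 2 (`CCOC(=O)c1c(N)sc(/N=C/c2ccc(N(C)C)cc2)c1C(=O)OCC`) gives 73000 nM
- compound 3 (`CCOC(=O)c1c(N)sc(/N=C/c2ccc(OC)cc2)c1C(=O)OCC`) gives 108000 nM

Compound 1 holds the lowest number of the three, and its steps to both others lie beyond the scatter. Compound 4 (`CCOC(=O)c1c(N)sc(/N=C/c2ccco2)c1C(=O)OCC`) is still unmeasured. It differs from compound 1 by hydrogen in place of nitro on an aromatic carbon, so 5-nitrofuran-2-yl becomes furan-2-yl.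

For the measured compounds named here, two measured steps bear on this, and both replace the whole 5-nitrofuran-2-yl group: a 9.6-fold higher number from compound 1 to compound 2 (0.98 log units; beyond the scatter) (modest) and a 14-fold higher number from compound 1 to compound 3 (1.15 log units; beyond the scatter) (large). The remaining step, a 1.5-fold higher number from compound 2 to compound 3 (0.17 log units; within the scatter), lies within the scatter. Going by the values given here, no measured compound isolates the nitro group, so these steps serve only as a rough guide. Since compound 4 keeps the furan ring, a step to a higher number, somewhat smaller than those two, is expected in this assay. For compound 4 the estimated value is 45000 nM with an expected range from 15000 nM to 120000 nM as its limits. This estimate means an expected change of a 5.9-fold higher number from compound 1 to compound 4 (0.77 log units; beyond the scatter) overall.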

Compound 4, half-maximal inhibitory concentration: 69300 nM
Beside the measured number, compound 4's estimate is 1.5-fold (0.19 log units) below it; low and high end bracket the measured number.
By their numbers in this assay, from the lowest: compound 1; then compounds 4, 2 and 3 (each within the scatter of the next).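

Taking only the nitro off the furan ring is enough to lose the standing of compound 1 in this assay: a 9.1-fold higher number from compound 1 to compound 4 (0.96 log units; beyond the scatter). Without the nitro, the furan-2-yl group no longer separates from the two substituted phenyl groups, with a 1.1-fold lower number from compound 2 to compound 4 (0.02 log units; within the scatter) and a 1.6-fold lower number from compound 3 to compound 4 (0.19 log units; within the scatter), both within the scatter. The data offer no measurement that explains why this nitro group matters to the cell read-out.

As far as these compounds go, it remains open whether the nitro group itself is needed at this position, or whether an amine, a nitrile or a carboxylic acid in its place would hold the lower number. Also open, from the compounds shown here alone, is whether a 4-nitrophenyl group would match 5-nitrofuran-2-yl, which would show whether the effect depends on the furan ring.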